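Swapping the Amide Aryl Group on a Piperazinyl Quinoline

The source may hold more compounds than are shown below. What is called first, only, known or untested is meant among the compounds shown, and "the series" means these compounds.

Three compounds share a core and were tested in a functional assay on MCF7 cells (Homo sapiens) for antiproliferative activity, read by MTT assay, with a stated time of 72 h; a lower number here means a stronger inhibitor, a higher number a weaker inhibitor. Compound 1 `Cc1cc(NCCN(C)C)nc2ccc(NC(=O)c3ccc(Cl)c(Cl)c3)cc12` gives 2550 nM, and compound 2 `CCN(CC)CCNc1cc(C)c2cc(NC(=O)c3ccc(Cl)c(Cl)c3)ccc2n1` gives 1420 nM; the step of a 1.8-fold lower number from compound 1 to compound 2 (0.25 log units; within the scatter) lies within the scatter. Compound 3 `CCN1CCN(c2cc(C)c3cc(NC(=O)c4ccc5ccccc5n4)ccc3n2)CC1` gives 7060 nM, the highest of the three numbers, and both other compounds sit beyond the scatter below it.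

Compound 4 `CCN1CCN(c2cc(C)c3cc(NC(=O)c4ccccc4Br)ccc3n2)CC1` differs from compound 3 in one place: 2-bromophenyl in place of quinolin-2-yl on a carbonyl carbon. No measured step changes the group on the carbonyl carbon, so nothing shown bears directly on this change. Compounds 1 and 2 carry a different aryl amide and lower numbers than compound 3, but they also differ in the amine, so their values cannot be assigned to the amide alone. Compound 4 is therefore expected to move only modestly, with the step of a 1.6-fold lower number from compound 3 to compound 4 (0.20 log units; within the scatter) estimated toward a somewhat lower number. For compound 4 the estimate in this assay is 4500 nM, within 1500 nM to 14000 nM.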

Compound 4, half-maximal inhibitory concentration: 27500 nM
The estimate for compound 4 lay 6.1-fold (0.79 log units) below the measured number; the whole stated range lies below it.
By their numbers in this assay, from the lowest: compounds 2 and 1 (each within the scatter of the next); then compound 3; then compound 4.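

In this assay, the swap of quinolin-2-yl for 2-bromophenyl on a carbonyl carbon gives a 3.9-fold higher number from compound 3 to compound 4 (0.59 log units; beyond the scatter). Among the compounds shown here, this is the first step at this place with the rest of the structure unchanged, so it shows that the group on the carbonyl carbon alone can move the number beyond the scatter, which the earlier compounds could not show because they also differed in the amine. Nothing measured here accounts for the direction or size of this step.

The pair leaves open whether the step follows from the loss of quinolin-2-yl or from the bromine itself, and a plain phenyl group on the carbonyl carbon would separate the two. As far as these compounds go, it also remains open how the dichlorophenyl amide of compounds 1 and 2 would compare on the ethylpiperazine.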